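From isopropyl to butoxy: compound 3 to compound 4

The compounds below may be only part of what the source reports. "The series", "measured", "known", "first", "only" and "open" are said of these compounds alone.

Measured in an ADME assay on HCT-116 cells (Homo sapiens) for cytotoxicity, read by CellTiter-Glo, with a stated time of 72 h; a higher number here means a weaker inhibitor, a lower number a stronger inhibitor:
Compound 1 `COc1ccccc1-c1ccc(S(=O)(=O)N2CCC(N3CCC(C)CC3)CC2)cc1`: > 5000 nM
Compound 2 `CCc1ccc(S(=O)(=O)N2CCC(N3CCC(C)CC3)CC2)cc1`: > 5000 nM
Compound 3 `CC1CCN(C2CCN(S(=O)(=O)c3ccc(C(C)C)cc3)CC2)CC1`: > 5000 nM

Each of these entries is a limit and not a number. Compound 3 stands at > 5000 nM, which is a limit. It shares that reading with both of the other compounds: the limit of > 5000 nM in this assay, at which 3 of the 3 values shown sit.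

Compound 4 `CCCCOc1ccc(S(=O)(=O)N2CCC(N3CCC(C)CC3)CC2)cc1` has not yet been measured. It carries butoxy in place of isopropyl on an aromatic carbon, para to a large group: butoxy in place of isopropyl on an aromatic carbon.

Within the data shown here, three measured steps bear on this change. Two of them also exchange a group on an aromatic carbon: a step that the two limits leave unreadable from compound 1 to compound 2, and a step that the two limits leave unreadable from compound 1 to compound 3. The third is a step that the two limits leave unreadable from compound 2 to compound 3. Among the measured compounds shown here, none of the three has a size that can be read, so they offer no measured precedent for a real shift in this assay. Compound 4 is therefore expected to stay with the other compounds, and a limit is the most likely report.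

The expected change is a step that the limit leaves unreadable from compound 3 to compound 4, with no firm direction expected.

For compound 4 the estimated value is 8000 nM, with an expected range from 3000 nM to 20000 nM.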

Compound 4, half-maximal inhibitory concentration: > 5000 nM
Compound 4: no number, only a limit (the forecaster's own chance of this, stated with the estimate: 80%); the middle value lies beyond the limit too.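

In this assay compound 4 gives a limit and not a number, as do compound 1, compound 2 and compound 3, so no step from any of them to compound 4 can be read: the limit of > 5000 nM in this assay, at which 4 of the 4 values shown sit.

The compounds shown leave open whether any group at this aromatic carbon would give a readable value in this assay.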